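A cyano group added to compound 2

The compounds below may be only part of what the source reports. "The series", "measured", "known", "first", "only" and "open" are said of these compounds alone.

Measured in a physicochemical assay for solubility, in phosphate buffer, with a stated time of 18 h, at pH 7; a higher number here means a more soluble compound, a lower number a less soluble compound:
Compound 1 `CC(C)CN1C(=O)c2ccccc2[C@H](C(=O)Nc2ccc(F)c(C#N)c2)[C@H]1c1ccsc1`: < 1000 nM, a limit of the assay
Compound 2 `CC(C)CN1C(=O)c2ccccc2[C@H](C(=O)Nc2ccc(F)c(C#N)c2)[C@H]1c1cccnc1`: 55000 nM

Among the measured compounds shown here, compound 2 holds the only actual number here, 55000 nM. Compound 3 `CC(C)CN1C(=O)c2ccccc2[C@H](C(=O)Nc2ccc(F)c(C#N)c2)[C@H]1c1cncc(C#N)c1` differs from compound 2 by cyano in place of hydrogen on an aromatic carbon, a change from pyridin-3-yl to 5-cyanopyridin-3-yl. For the measured compounds named here, one measured step bears on this group, an at least 55-fold higher number from compound 1 to compound 2 (1.74 log units; beyond the scatter), a large step, but it swapped one ring for another and so guides the size only loosely. A moderate step down in this assay is expected, giving back part of that rise. The expected change is a 3.7-fold lower number from compound 2 to compound 3 (0.56 log units; beyond the scatter). Compound 3 is estimated at 15000 nM, with a range of 3000 nM to 60000 nM.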

Compound 3, solubility: 60000 nM
Compound 3: the middle estimate sits 4.0-fold (0.60 log units) below what was measured; the range from low to high includes it.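

In this assay, cyano on an aromatic carbon two atoms from the ring nitrogen leaves the read-out level (a 1.1-fold higher number from compound 2 to compound 3 (0.04 log units; within the scatter)). The rise over the thiophen-3-yl compound therefore survives with 5-cyanopyridin-3-yl in place of pyridin-3-yl (an at least 60-fold higher number from compound 1 to compound 3 (1.77 log units; beyond the scatter)). The value of compound 1 is a limit of the assay: the limit of < 1000 nM in this assay, at which 1 of the 3 values shown sits.

The compounds shown leave open whether an amine or a carboxylic acid on this same aromatic carbon would also leave the read-out level. They also leave open whether cyano would do so on the thiophen-3-yl ring.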